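The source may hold more compounds than are shown below. What is called first, only, known or untested is meant among the compounds shown, and "the series" means these compounds.

Working notes on the series, all read in an ADME assay on J774 cells (Mus musculus) for antiproliferative activity, with a stated time of 72 h; a lower number here means that less compound is needed, a higher number that more compound is needed for the effect. Compound 1 (`CCc1c(C)[nH]c2cc(OCCCO)c(Cl)cc2c1=O`) has no reading: "not determined" (no result reported). Compound 2 (`CCc1c(C)[nH]c2cc(OCCCN3CCN(c4ccccc4)CC3)c(Cl)cc2c1=O`) gives > 23000 nM, which is a limit and not a number. Going by the values given here, compound 3 (`CCCCc1cc2c(=O)c(-c3cccnc3)c(C)[nH]c2cc1OCCOc1ccccc1`) gives 23000 nM, the only actual number in the set, so it cannot yet be ranked against any measured neighbour. The one limit in the set is the limit of > 23000 nM in this assay, at which 1 of the 3 values shown sits.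

Compound 4 (`CCCCc1cc2c(=O)c(-c3ccc(Cl)cc3C)c(C)[nH]c2cc1OCCOc1ccccc1`) is the next compound to be read. Its change from compound 3 is 4-chloro-2-methylphenyl in place of pyridin-3-yl on an aromatic carbon. In words, 4-chloro-2-methylphenyl stands in place of pyridin-3-yl on an aromatic carbon, and the hydrogen-bond acceptor of the leaving group is not replaced.

Among the compounds with values here, no measured step covers this exchange, so the expectation is loose. Starting from compound 3 at 23000 nM, a modest move toward lower concentration in this assay is expected. A reading that is again only a limit remains possible for compound 4. The estimated step is a 2.3-fold lower number from compound 3 to compound 4 (0.36 log units; beyond the scatter). For compound 4 the expected value is 10000 nM, with an estimated range of 3500 nM to 23000 nM.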

Compound 4, half-maximal effective concentration: > 21000 nM
Compound 4: only a limit was reported (the forecaster's own chance of this, stated with the estimate: 30%); at least 2.1-fold (0.32 log units) between middle value and limit.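

Compound 4 reads > 21000 nM in this assay, which is a limit and not a number, so no step can be read between compound 3 and compound 4. The compounds shown leave open whether 4-chloro-2-methylphenyl in place of pyridin-3-yl on an aromatic carbon changes the half-maximal effective concentration at all, and in which direction.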